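A few compounds are considered here, and "the series" means these few. Any claim that something is new, unique, unknown or untested is made for them only; others in the source may bear on it.

Measured so far:
compound 1, `CN(C)c1ccc(-c2cccc(N)c2)cc1` — in an assay on COS-7 cells for inhibition of patatin-like phospholipase domain-containing protein 2 (Mus musculus) (on this read-out higher numbers stand for weaker inhibition and lower numbers for stronger inhibition), compound 1 gives 100000 nM
compound 2, `CC(C)OC(=O)Nc1cccc(-c2ccc(N(C)C)cc2)c1` — in this assay compound 2 gives 82000 nM

Compound 2 carries the lowest of these two numbers, but its nearest neighbour is compound 1, and the step of a 1.2-fold lower number from compound 1 to compound 2 (0.09 log units; within the scatter) does not reach beyond the scatter, so the two values cannot be told apart. Compound 3, `CC(C)COC(=O)Nc1cccc(-c2ccc(N(C)C)cc2)c1`, is the next compound and has not yet been measured. It differs from compound 2 by isobutyl in place of isopropyl on an oxygen next to a carbonyl group; the carbamate itself and the shared core stay as they are. Among the compounds with values here, no measured step touches this position: the only step, a 1.2-fold lower number from compound 1 to compound 2 (0.09 log units; within the scatter), concerns the nitrogen on the aromatic ring, not the alkyl group on the oxygen. With nothing to lean on, the expectation is a step of no more than the scatter in this assay, in either direction. The estimate for compound 3 is therefore 80000 nM, with a range from 30000 nM to 200000 nM, which is expected to mean a 1.0-fold lower number from compound 2 to compound 3 (0.01 log units; within the scatter).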

Compound 3, half-maximal inhibitory concentration: 22000 nM
Estimate against measurement, compound 3: 3.6-fold (0.56 log units) above; measured number below the stated range.
By their numbers in this assay, from the lowest: compound 3; then compounds 2 and 1 (each within the scatter of the next).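

In this assay, within the data shown here, the alkyl group on an oxygen next to a carbonyl group turns out to count: isobutyl in place of isopropyl gives the first step that lies beyond the scatter (a 3.7-fold lower number from compound 2 to compound 3 (0.57 log units; beyond the scatter)). With isobutoxycarbonyl on the nitrogen, the comparison with the hydrogen of compound 1 also clears the scatter (a 4.5-fold lower number from compound 1 to compound 3 (0.66 log units; beyond the scatter)), which the isopropoxycarbonyl group did not do. So the effect of capping that nitrogen depends on the chain carried by the oxygen, and no measurement available here explains why.

On these data alone, whether a longer chain such as n-butyl, or a ring-bearing group such as benzyl, on the same oxygen would lower the number further remains open. So does whether a urea in place of the carbamate would preserve the step.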